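Enlarging the hydrazone arm on a shared dihydropyridine-free core

The compounds below may be only part of what the source reports. "The series", "measured", "known", "first", "only" and "open" are said of these compounds alone.

Three compounds on one shared core are compared, each differing only in the group that hangs from the hydrazone amine nitrogen. Compound 2 `CCOC(=O)C1=C(NN=C(C#N)C#N)Nc2[nH]nc(C)c2C1c1ccc(N(C)C)cc1` carries a small dinitrile-bearing group there, and in a functional assay on MCF7 cells (Homo sapiens) for inhibition, read by MTT assay, with a stated time of 48 h (a higher number here means a weaker inhibitor, a lower number a stronger inhibitor), compound 2 gives 12100 nM, the lowest of the two numbers obtained. Compound 3 `CCOC(=O)C1=C(N/N=C(/C(=O)Br)c2ccc(Br)cc2)Nc2[nH]nc(C)c2C1c1ccc(N(C)C)cc1` carries instead a larger group with a six-membered aromatic ring, and in this assay compound 3 gives 61300 nM. Going by the values given here, the step of a 5.1-fold higher number from compound 2 to compound 3 (0.70 log units; beyond the scatter) is the only measured step that alters this arm.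

Compound 1 `CCOC(=O)C1=C(N/N=C(\c2ccc([N+](=O)[O-])cc2)N2CCN(c3ccc(F)cc3)CC2)Nc2[nH]nc(C)c2C1c1ccc(N(C)C)cc1` sits at the limit of > 100000 nM in this assay, at which 1 of the 3 values shown sits; in this assay compound 1 gives > 100000 nM, which is a limit of the assay and not a number.

Compound 4 `CCOC(=O)C1=C(N/N=C(/Cl)c2ccc([N+](=O)[O-])cc2)Nc2[nH]nc(C)c2C1c1ccc(N(C)C)cc1` has not yet been measured. Against compound 2 it shows (a group of 12 heavy atoms (7 carbon, 2 nitrogen, 2 oxygen, 1 chlorine; one six-membered aromatic ring of carbon only) in place of a group of 6 heavy atoms (3 carbon, 3 nitrogen; no ring), on an amine nitrogen). Among the compounds with values here, the sole step that bears on this change is a 5.1-fold higher number from compound 2 to compound 3 (0.70 log units; beyond the scatter), which also brought a six-membered aromatic ring onto the same amine nitrogen and moved the number modestly upward, beyond the scatter. A step of comparable size and direction is therefore expected, namely a 3.3-fold higher number from compound 2 to compound 4 (0.52 log units; beyond the scatter). For compound 4 in this assay the estimate is 40000 nM, within a range from 12000 nM to 130000 nM.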

Compound 4, half-maximal inhibitory concentration: 52700 nM
Beside the measured number, compound 4's estimate is 1.3-fold (0.12 log units) below it, and the stated range covers the measured number.
By their numbers in this assay, from the lowest: compound 2; then compounds 4 and 3 (each within the scatter of the next). At a limit, above all of these: compound 1.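

In this assay the change on the amine nitrogen now has a second reading (a 4.4-fold higher number from compound 2 to compound 4 (0.64 log units; beyond the scatter)), so the upward move seen with compound 3 is not confined to a single enlarged group. The two enlarged groups, each with a six-membered aromatic ring of carbon only, cannot be told apart (a 1.2-fold lower number from compound 3 to compound 4 (0.07 log units; within the scatter)), although one holds chlorine and two oxygen atoms where the other holds bromine, so on these compounds that difference in the arm leaves the number unmoved beyond the scatter. Compound 1, whose arm also holds a six-membered aromatic ring, gives > 100000 nM as a limit of the assay and not a number.

Greater size and the aromatic ring enter together in both steps from compound 2, so the compounds shown do not separate the two, and an arm with a single nitrile, a carboxylic acid or a short alkyl chain on the same position would be needed to tell them apart. Nothing shown here gives a measured reason for any of these steps.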